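The source may hold more compounds than are shown below. What is called first, only, known or untested is meant among the compounds shown, and "the series" means these compounds.

Measured so far:
compound 1 `CO/C(=C\c1ccccc1)C(=O)Nc1ccc(Cl)cc1` – 17000 nM
compound 2 `CO/C(=C\c1ccc(F)cc1)C(=O)Nc1ccc(Cl)cc1` – 9480 nM

Both numbers come from a functional assay on cells (Splenocyte, Mus musculus, strain BALB/c) for inhibition, read by MTT assay, with a stated time of 48 h; a lower number here means a stronger inhibitor, a higher number a weaker inhibitor. In this assay compound 1 gives 17000 nM and compound 2 gives 9480 nM. Within the data shown here, the single measured step, a 1.8-fold lower number from compound 1 to compound 2 (0.25 log units; within the scatter), is within the scatter, so compound 2 and compound 1 are not separated by these two numbers; compound 2 simply carries the fluoro that compound 1 lacks and stands with its one neighbour on the same footing.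

The next compound is compound 3 `CO/C(=C\c1ccc(F)cc1)C(=O)Nc1ccc(OC)cc1`. It differs from compound 2 in one place: methoxy in place of chloro on an aromatic carbon. Among the measured compounds shown here, no measured step concerns this change; the only step in hand, a 1.8-fold lower number from compound 1 to compound 2 (0.25 log units; within the scatter), exchanges hydrogen for fluoro on the other ring and says nothing about methoxy replacing chloro. For the measured compounds named here, with no bearing step and the one available step within the scatter, the expectation for compound 3 is a step in this assay of about a 1.3-fold higher number from compound 2 to compound 3 (0.10 log units; within the scatter), that is, none beyond the scatter. Compound 3 is therefore estimated at 12000 nM, in the range 4000 nM to 40000 nM.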

Compound 3, half-maximal inhibitory concentration: 13500 nM
Compound 3: the middle estimate sits 1.1-fold (0.05 log units) below what was measured, and the stated range covers the measured number.
By their numbers in this assay, from the lowest: compounds 2, 3 and 1 (each within the scatter of the next).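

In this assay the exchange of chloro for methoxy, on an aromatic carbon of a six-membered aromatic ring of carbon only and para to a large group, gives a 1.4-fold higher number from compound 2 to compound 3 (0.15 log units; within the scatter) and so does not separate the two groups at this position. Among these compounds, the earlier step, a 1.8-fold lower number from compound 1 to compound 2 (0.25 log units; within the scatter) on replacing hydrogen with fluoro, concerned the other ring, so this is the first reading at the position that carries chloro: chloro, with 1 heavy atom and no hydrogen-bond acceptor, gives way to methoxy, with 2 heavy atoms and 1 hydrogen-bond acceptor, and the step stays within the scatter. No independent measurement bears on this result, so no account of it can be offered.

Only chloro and methoxy are shown at this position, so it remains open whether an amine, a carboxylic acid or a longer alkoxy chain there would move the number beyond the scatter. Also open, from the compounds shown here alone, is whether methoxy at this position reads the same when the other ring carries hydrogen in place of fluoro, as in the core of compound 1.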